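Methyl added to compound 3 on the outer phenyl ring

The compounds below may be only part of what the source reports. "The series", "measured", "known", "first", "only" and "open" are said of these compounds alone.

Working notes on the anilide series around a shared core. Compound 1 `Cc1ccc(-c2ccc(C(=O)Nc3ccc(Oc4ccnc5[nH]ccc45)cc3)nc2)cc1` carries a 4-methylphenyl on the outer ring and no fluorine on the anilide ring. In a functional assay on A549 cells (Homo sapiens) for cytotoxicity, read by MTT assay, with a stated time of 72 h (on this read-out higher numbers stand for weaker inhibition and lower numbers for stronger inhibition), compound 1 gives only a limit, > 10000 nM, which is a limit of the assay and not a number; (the limit of > 10000 nM in this assay, at which 1 of the 3 values shown sits). Compound 2 `COc1ccc(-c2ccnc(C(=O)Nc3ccc(Oc4ccnc5[nH]ccc45)cc3)c2)cc1` places a methoxyphenyl on a differently substituted outer ring, and in this assay compound 2 gives 6970 nM. Compound 3 `O=C(Nc1ccc(Oc2ccnc3[nH]ccc23)c(F)c1)c1ccc(-c2ccccc2)cn1` keeps an unsubstituted phenyl and adds fluorine to the anilide ring; in this assay compound 3 gives 1250 nM, the lowest of the two numbers reported, clearly apart from compound 2.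

Compound 4 `Cc1ccc(-c2ccc(C(=O)Nc3ccc(Oc4ccnc5[nH]ccc45)c(F)c3)nc2)cc1` differs from compound 3 by methyl in place of hydrogen on an aromatic carbon, para to a large group. Among the compounds with values here, no measured pair isolates this change. Compound 1 and compound 3 differ in two places, so their values show only that the methyl-bearing, fluorine-free analogue reached no number. A step in this assay from compound 3 to compound 4 toward weaker inhibition is expected, a 3.2-fold higher number from compound 3 to compound 4 (0.51 log units; beyond the scatter). Compound 4 is estimated at 4000 nM, within 1500 nM to 12000 nM.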

Compound 4, half-maximal inhibitory concentration: 2300 nM
For compound 4 the middle estimate is 1.7-fold (0.24 log units) above the measured one; low and high end bracket the measured number.
By their numbers in this assay, from the lowest: compounds 3 and 4 (each within the scatter of the next); then compound 2. At a limit, above all of these: compound 1.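

On the outer phenyl ring, the methyl para to a large group leaves no readable change in this assay: a 1.8-fold higher number from compound 3 to compound 4 (0.26 log units; within the scatter), so with fluorine on the anilide ring, phenyl and 4-methylphenyl cannot be told apart here. With the 4-methylphenyl held constant, fluorine on the anilide ring now forms a single-change pair, and that change is the one that counts: an at least 4.3-fold lower number from compound 1 to compound 4 (0.63 log units; beyond the scatter). The entry for compound 1 is a limit of the assay and not a number: the limit of > 10000 nM in this assay, at which 1 of the 4 values shown sits.

As far as these compounds go, whether fluorine has a similar effect with the unsubstituted phenyl stays open, as compound 3 has no fluorine-free partner here. Also open, from the compounds shown here alone, is whether an amine or a carboxylic acid at the same outer-ring position would move the number beyond the scatter.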